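The source may report more compounds than this note shows. Statements on the series, on what has been measured and on what is new or still open speak of the compounds shown alone.

Measured so far in an ADME assay on L929 cells (Mus musculus) for cytotoxicity, read by resazurin assay, with a stated time of 48 h; a lower number here means that less compound is tolerated, a higher number that more compound is tolerated
Compound 1 `COC(=O)Cn1c2ccc([N+](=O)[O-])cc2c(=O)n1Cc1ccccc1` gives 129000 nM as a number
Compound 2 `O=C(O)CCCn1c2ccc([N+](=O)[O-])cc2c(=O)n1Cc1ccccc1` gives > 256000 nM as a limit

Compound 2 has no number, only the limit > 256000 nM in this assay as its standing. Compound 3 `NC(=O)CCCn1c2ccc([N+](=O)[O-])cc2c(=O)n1Cc1ccccc1` has amino in place of hydroxy on a carbonyl carbon, carboxy becoming carbamoyl amino in place of hydroxy on a carbonyl carbon with the rest unchanged. Within the data shown here, only one measured step bears on this, and it is a different change: an at least 1.9-fold higher number from compound 1 to compound 2 (0.29 log units; that floor lies within the scatter) is its size. No step beyond the scatter is therefore expected in this assay, in either direction. The estimated step is an at least 1.2-fold lower number from compound 2 to compound 3 (0.10 log units; that floor lies within the scatter) as expected here. Compound 3 is expected at 200000 nM with an estimated range of 100000 nM to 300000 nM for the coming measurement.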

Compound 3, concentration lethal to 50% of the cells: > 256000 nM
Compound 3 ended at the assay's limit; the forecaster's own chance of this, stated with the estimate: 40%; middle value at least 1.2-fold (0.10 log units) away from the limit.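

In this assay compound 3 gives only a limit, > 256000 nM, so amino in place of hydroxy on a carbonyl carbon leaves the series at the same ceiling as compound 2. The size of that change cannot be read, because neither compound has a number: the limit of > 256000 nM in this assay, at which 2 of the 3 values shown sit.

Among these compounds, the one readable step is an at least 1.9-fold higher number from compound 1 to compound 3 (0.29 log units; that floor lies within the scatter).

From the compounds shown here alone, whether an amine or a longer chain in place of 2-carbamoylethyl would give a number in this assay stays open. So does the true distance between compound 2 and compound 3.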